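Swapping the hydroxyphenyl of compound 2 for a methylpyrrole

A few compounds are considered here, and "the series" means these few. Any claim that something is new, unique, unknown or untested is made for them only; others in the source may bear on it.

In an assay on isolated protein for displacement of a labelled ligand from 5-hydroxytryptamine receptor 6 (Homo sapiens) (a lower number here means a stronger inhibitor, a higher number a weaker inhibitor), compound 2 `NC[C@@H]1CCCc2cc(S(=O)(=O)c3cccc(O)c3)ccc21` gives 0.251 nM, the lowest number among the three measured compounds. Compound 1 `CC(=N)NCC1CCCc2cc(S(=O)(=O)c3ccccc3)ccc21` gives 0.631 nM in this assay, and compound 3 `CS(=O)(=O)c1cccc(S(=O)(=O)c2ccc3c(c2)CCC[C@H]3CN)c1` gives 3.98 nM. Within the data shown here, the only single-point step recorded, a 16-fold higher number from compound 2 to compound 3 (1.20 log units; beyond the scatter), shows how much weaker the binding became when the hydroxy was replaced.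

Compound 4 `Cn1ccc(S(=O)(=O)c2ccc3c(c2)CCC[C@H]3CN)c1` differs from compound 2 by 1-methyl-1H-pyrrol-3-yl in place of 3-hydroxyphenyl on a sulfonyl sulfur. Among the measured compounds shown here, no measured step involves a 1-methyl-1H-pyrrol-3-yl, so the expectation rests on indirect evidence: the large loss in a 16-fold higher number from compound 2 to compound 3 (1.20 log units; beyond the scatter) when the hydroxy was replaced, and the gap between compound 2 and compound 1, whose phenyl carries no hydroxy, although compound 1 also differs elsewhere. The change removes a hydrogen-bond donor, so a moderate rise in this assay is expected, smaller than a 16-fold higher number from compound 2 to compound 3 (1.20 log units; beyond the scatter), that is a 3.2-fold higher number from compound 2 to compound 4 (0.50 log units; beyond the scatter). Compound 4 is therefore estimated at 0.8 nM, with a range from 0.25 nM to 3 nM.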

Compound 4, inhibition constant: 7.94 nM
For compound 4 the middle estimate is 9.9-fold (1.00 log units) below the measured one, outside the stated range (above it).
By their numbers in this assay, from the lowest: compound 2; then compound 1; then compounds 3 and 4 (each within the scatter of the next).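

Replacing the whole aryl group on a sulfonyl sulfur proves as damaging as the earlier change to its hydroxy: the step to 1-methyl-1H-pyrrol-3-yl is large (a 32-fold higher number from compound 2 to compound 4 (1.50 log units; beyond the scatter)) in this assay, and compound 3 (3.98 nM) and compound 4 (7.94 nM) lie within the scatter of each other. Two quite different replacements of 3-hydroxyphenyl therefore both lose most of the binding that compound 2 shows, so the tight binding of compound 2 does not survive either change. Nothing shown here accounts for this loss.

As far as these compounds go, it remains open whether the loss follows the hydroxy alone or the ring that carries it, a question that a plain phenyl on the same core could address. Equally open, from the compounds shown here alone, is how a 3-aminophenyl or a pyrrol-3-yl without its methyl would behave here.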